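Amide variation on a shared core at the adenosine receptor

A few compounds are considered here, and "the series" means these few. Any claim that something is new, unique, unknown or untested is made for them only; others in the source may bear on it.

Measured so far in an assay on CHO cells for displacement of a labelled ligand from adenosine receptor A1 (Homo sapiens), read by scintillation counting, with a stated time of 120 min, tested at 1 uM; on this read-out higher numbers stand for more inhibition at the one concentration tested (going by the name of the read-out) and lower numbers for less inhibition:
compound 1 `COc1ccc(-n2cc3nc(C)nc(NC(=O)c4ccco4)c3n2)cc1`: 6%
compound 2 `Cc1nc(NC(=O)c2cccnc2)c2nn(-c3ccccc3)cc2n1`: 12%

Both measured amides sit at the low end of the percentage scale in this assay. Compound 1 gives 6%. Compound 2 gives 12%. Of the two numbers, compound 2 is the one written highest, but its distance to compound 1 is within the scatter, so the two compounds read alike: little displacement of the labelled ligand at the single concentration tested.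

Compound 3 `Cc1nc(NC(=O)c2ccncc2)c2nn(-c3ccccc3)cc2n1` is the next member and has not yet been measured in this assay. It shares the core and the amide of compound 2; the difference lies in the ring on the carbonyl carbon:

pyridin-4-yl in place of pyridin-3-yl on a carbonyl carbon

Going by the values given here, no step between measured compounds covers this change, and the two measured values give only a low baseline to work from. The step from compound 2 to compound 3 is expected to be none beyond the scatter, in either direction: a number 2 percentage points lower from compound 2 to compound 3 (within the scatter). Compound 3 is therefore estimated at 10% in this assay, with a range from 0% to 30%.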

Compound 3, a percentage reported as inhibition, at one concentration (the size of the read-out at that concentration, not a potency): 12%
Estimate against measurement, compound 3: 2 percentage points below, within the range that was stated.
By their numbers in this assay, from the lowest: compounds 1, 2 and 3 (each within the scatter of the next).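

In this assay, pyridin-4-yl in place of pyridin-3-yl on a carbonyl carbon gives no change at the digits printed from compound 2 to compound 3 (within the scatter) and is the only step shown between compounds that differ in one place. The two groups have the same atoms, joined differently, and the same counts of hydrogen-bond donors and acceptors; this rearrangement alone leaves compound 3 at 12%, still at the low end of the percentage scale. The data give no explanation for this flat result.

Still open, on these data alone, is whether this position responds to a larger change, such as a plain phenyl ring, a pyridin-3-yl ring carrying an amine or a carboxylic acid, or a longer chain between the carbonyl and the ring. With readings from only one concentration and all of them low, the compounds shown also leave open whether pyridin-3-yl and pyridin-4-yl would separate at any other concentration, and whether the phenyl group on the shared core contributes to the low numbers.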